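The source may hold more compounds than are shown below. What is called first, only, known or untested is meant among the compounds shown, and "the series" means these compounds.

Working notes on the series in an assay on isolated protein for inhibition of Death-associated protein kinase 3 (Homo sapiens), tested at 10 uM; a higher number here means a stronger effect of the compound at the concentration tested, a lower number a weaker effect. Of the compounds shown here, three carry numbers so far. Compound 1 `O=C1OC(c2ccc(Cl)c([N+](=O)[O-])c2)=N/C1=C\c1ccncc1` gives 10% in this assay. Compound 2 `O=C1OC(c2cccc(Br)c2)=N/C1=C\c1ccncc1` gives 0% in this assay. Compound 3 `O=C1OC(c2ccc(Cl)cc2Cl)=N/C1=C\c1cccnc1` gives 78% in this assay.

Compound 2 stands lowest of the three numbers. Its nearest neighbour is compound 1, whose number lies higher by an amount within the scatter, so the two cannot be told apart on these data. The furthest is compound 3, whose number lies higher by an amount beyond the scatter.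

The next compound to be measured is compound 4 `O=C1OC(c2cccc([N+](=O)[O-])c2)=N/C1=C\c1ccncc1`. Set against compound 2 it shows one difference (nitro in place of bromo on an aromatic carbon), on an aromatic carbon of a six-membered aromatic ring of carbon only, meta to a large group.

Within the data shown here, no step between two measured compounds has been computed for this pair, so the size of the step rests on what compound 1 and compound 2 show: two compounds with a nitro group present or absent sit within the scatter of each other. On that basis the step from compound 2 to compound 4 is expected to be small, in either direction, and not beyond the scatter: a number 8 percentage points higher from compound 2 to compound 4 (within the scatter) is the expected step.

Compound 4 is therefore estimated at 8% in this assay, with a range from 0% to 25%.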

Compound 4, a percentage reported as inhibition, at one concentration (the size of the read-out at that concentration, not a potency): 0%
Estimate against measurement, compound 4: 8 percentage points above; measured number inside the range.
By their numbers in this assay, from the lowest: compounds 2, 4 and 1 (each within the scatter of the next); then compound 3.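

In this assay, nitro in place of bromo on an aromatic carbon, meta to a large group, gives no change at the digits printed from compound 2 to compound 4 (within the scatter), so the two groups cannot be told apart at this position on these data. Among these compounds, the second comparison holds the nitro group in place: hydrogen in place of chloro on an aromatic carbon gives a number 10 percentage points lower from compound 1 to compound 4 (within the scatter), so the chloro group also has no effect that can be read beyond the scatter, and the series now has two single-place comparisons where the earlier compounds offered none. No measurement available here bears on the reason for these numbers.

Among the compounds shown here, whether an amine, a carboxylic acid or a longer chain on that aromatic carbon would move the number in this assay remains open, as both steps rest on only three compounds with low numbers. Compound 3 differs from each of the other compounds in more than one place, so the steps to it cannot be read, and which of its differences goes with its higher number stays unresolved.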